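The source may report more compounds than this note shows. Statements on the series, on what has been measured and on what is new or still open speak of the compounds shown alone.

Measured so far:
compound 1, `COc1ccc(OCC2=NCCO2)cc1`, 64.1%
compound 2, `Cc1ccccc1OCC1=NCCO1`, 55.3%

Both compounds share one core and differ only in the group carried on the aromatic ring. In a functional assay on the whole organism for inhibition, with Rattus norvegicus as the target, read by paw edema, with a stated time of 30 min, at a dose of 80 mg/kg by the oral route (a lower number here means a weaker effect, a higher number a stronger effect of the compound at the dose given), compound 1 gives 64.1%, while compound 2 gives 55.3%. Compound 1 stands at the top of these two numbers, but only by a margin that lies within the scatter of repeated measurements, so the two cannot be told apart with confidence.

Compound 3, `Brc1ccc(OCC2=NCCO2)cc1`, has not yet been tested in this assay. It differs from compound 1 in one place: bromo in place of methoxy on an aromatic carbon. Among the compounds with values here, no pair of measured compounds shows this change, so nothing measured here speaks for or against it; the two numbers at hand merely fall in the same middle range. Only a small step, if any, is expected, with no clear direction: a number 4.1 percentage points lower from compound 1 to compound 3 (within the scatter). Compound 3 is therefore estimated to give about 60% in this assay, within the range 45% to 75%.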

Compound 3, a percentage reported as inhibition, in the whole organism at one dose (the size of the read-out at that dose, not a potency): 60.1%
Beside the measured number, compound 3's estimate is 0.1 percentage points below it; the measured number falls inside the stated range.
By their numbers in this assay, from the lowest: compounds 2, 3 and 1 (each within the scatter of the next).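

In this assay, bromo in place of methoxy on an aromatic carbon, para to a group of 7 heavy atoms, gives a number 4 percentage points lower from compound 1 to compound 3 (within the scatter) and so leaves the read-out within the usual scatter. For this pair, then, the oxygen-bearing methoxy, with its hydrogen-bond acceptor, is not needed to keep the effect at this dose: a single bromine atom, which counts no acceptor, serves as well as far as this measurement can tell. Nothing available explains why these two groups give matching numbers.

From the compounds shown here alone, it remains open whether a very different group at this position, such as an amine, a carboxylic acid or a longer chain, would also leave the read-out in place. A single dose also leaves open whether compound 1 and compound 3 would still match at other doses.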